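Same Atoms, Joined Differently: What Compound 4 May Show

A few compounds are considered here, and "the series" means these few. Any claim that something is new, unique, unknown or untested is made for them only; others in the source may bear on it.

In an ADME assay on the whole organism (Rattus norvegicus) for pharmacokinetics, at a dose of 1 mg/kg by the intravenous route (a higher number here means more compound in the circulation at the dose given, a lower number less compound in the circulation), compound 1 (`Cc1nnc(N2CCC(C(=O)N3N=CC[C@H]3c3ccccc3)CC2)o1`) gives 800 ng.h/mL, compound 2 (`N#Cc1cnc(N2CCC(C(=O)N3N=CC[C@H]3c3cc(F)cc(F)c3)CC2)cn1`) gives 400 ng.h/mL and compound 3 (`O=C(c1c[nH]nn1)N1CCC(C(=O)N2N=CCC2c2ccccc2)CC1`) gives 450 ng.h/mL. Compound 2 lies within the usual scatter of both others, so these three numbers cannot be ranked. Compound 4 (`N#Cc1cc(N2CCC(C(=O)N3N=CC[C@H]3c3cc(F)cc(F)c3)CC2)ncn1`) keeps the atoms of compound 2 but joins them differently: a group of 8 heavy atoms (5 carbon, 3 nitrogen; one six-membered aromatic ring with 2 hetero atoms) in place of a group of 8 heavy atoms (5 carbon, 3 nitrogen; one six-membered aromatic ring with 2 hetero atoms), on an amine nitrogen in a ring. The 5-cyanopyrazin-2-yl group leaves, and the new group sits on the same amine nitrogen in a ring. For the measured compounds named here, no measured pair shows what such a swap does in this assay, so the value of compound 2, 400 ng.h/mL, is the best starting point. The expected change is a 1.1-fold higher number from compound 2 to compound 4 (0.05 log units; within the scatter), which stays within the scatter. For compound 4, the estimated value is 450 ng.h/mL, with an expected range of 180 ng.h/mL to 1100 ng.h/mL.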

Compound 4, area under the concentration-time curve: 410 ng.h/mL
Beside the measured number, compound 4's estimate is 1.1-fold (0.04 log units) above it; measured number inside the range.
By their numbers in this assay, from the lowest: compounds 2, 4, 3 and 1 (each within the scatter of the next).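

For the compounds shown here, the swap gives a 1.0-fold higher number from compound 2 to compound 4 (0.01 log units; within the scatter) in this assay and is the first step in this set that can be read. At this place, on an amine nitrogen in a ring, joining the same atoms differently leaves the number within the scatter. No measurement here offers a reason for this result.

As far as these compounds go, whether a pyridine ring carrying a nitrile, or a carboxylic acid, on this same amine nitrogen would move the number beyond the scatter stays open. This single pair also cannot say whether the same swap would behave alike on the core of compound 1.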